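Swapping Ethoxy for Trifluoromethylcyclopropyl on a Second Core

The source may report more compounds than this note shows. Statements on the series, on what has been measured and on what is new or still open speak of the compounds shown alone.

Compound 2 `CCOC(=O)N1CCC(NC(=O)Nc2ccc(OC(F)(F)F)c(F)c2)CC1` and compound 1 `O=C(Nc1ccc(OC(F)(F)F)c(F)c1)NC1CCN(C(=O)C2(C(F)(F)F)CC2)CC1` differ in one place: 1-(trifluoromethyl)cyclopropyl in place of ethoxy on a carbonyl carbon. In a physicochemical assay for lipophilicity, read by HPLC, with a stated time of 90 min, tested at 100 uM (a lower number here means a more polar compound, a higher number a more lipophilic compound), compound 2 gives 5.94 and compound 1 gives 5.94, so no change at the digits printed from compound 2 to compound 1 (within the scatter). Compound 3 `CCOC(=O)N1CCC(NC(=O)Nc2ccc(C(F)(F)F)c(F)c2)CC1` shares the core of compound 2 apart from one difference, (trifluoromethyl in place of trifluoromethoxy on an aromatic carbon); in this assay compound 3 gives 5.46, and a number 0.48 log units lower from compound 2 to compound 3 (beyond the scatter). Compound 4 `O=C(Nc1ccc(C(F)(F)F)c(F)c1)NC1CCN(C(=O)C2(C(F)(F)F)CC2)CC1` has not yet been measured in this assay. It stands to compound 3 as compound 1 stands to compound 2: 1-(trifluoromethyl)cyclopropyl in place of ethoxy on a carbonyl carbon. The surroundings of the changed carbonyl carbon are the same word for word, so this is the same kind of change carried onto the core of compound 3. Because no change at the digits printed from compound 2 to compound 1 (within the scatter), compound 4 is expected to take a step of similar size, no change at the digits printed from compound 3 to compound 4 (within the scatter). Compound 4 is therefore estimated to give 5.46, with a likely range from 5.1 to 5.85.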

Compound 4, partition coefficient: 5.52
Compound 4: middle estimate off by 0.06 log units, on the low side; the range from low to high includes it.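

In this assay, putting 1-(trifluoromethyl)cyclopropyl in place of ethoxy on the carbonyl carbon gives a number 0.06 log units higher from compound 3 to compound 4 (within the scatter), matching the earlier result on the other core, no change at the digits printed from compound 2 to compound 1 (within the scatter). The second swap, trifluoromethyl in place of trifluoromethoxy on an aromatic carbon, also repeats in direction, with a number 0.42 log units lower from compound 1 to compound 4 (beyond the scatter) set against a number 0.48 log units lower from compound 2 to compound 3 (beyond the scatter). This shows the change carrying over between these two cores only, not across the series, and nothing given here accounts for the result.

Still open, going by these compounds, is how the same swap would read on a core with a nitrile or a methoxy group on that aromatic carbon. Also open, on these data alone, is how an amine or a carboxylic acid on the carbonyl-bearing group would compare.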